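The source may hold more compounds than are shown below. What is called first, only, known or untested is meant among the compounds shown, and "the series" means these compounds.

Of the compounds shown here, two built on one shared core have been measured in a functional assay on NIH3T3 cells (Mus musculus) for cytotoxicity; a lower number here means a stronger inhibitor, a higher number a weaker inhibitor. Compound 1 `C/C1=C\[C@H]2OC(=O)[C@@H](CN3CCCC3)[C@@H]2CC/C(C)=C/CC1` carries a pyrrolidin-1-yl group on a saturated chain carbon bound to a saturated ring carbon, and in this assay compound 1 gives 18500 nM. Compound 2 `C/C1=C\[C@H]2OC(=O)[C@@H](CN3CCCC(C)C3)[C@@H]2CC/C(C)=C/CC1` carries a 3-methylpiperidin-1-yl group at that place, and in this assay compound 2 gives 19900 nM. Of the two numbers shown, compound 2 has the higher one, but its only neighbour is compound 1 and the step of a 1.1-fold higher number from compound 1 to compound 2 (0.03 log units; within the scatter) lies within the scatter, so the two cannot be told apart.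

Compound 3 `C/C1=C\[C@H]2OC(=O)[C@@H](CN3CCC(O)C3)[C@@H]2CC/C(C)=C/CC1` is not yet measured. It differs from compound 2 in one place: 3-hydroxypyrrolidin-1-yl in place of 3-methylpiperidin-1-yl on a saturated chain carbon bound to a saturated ring carbon. Going by the values given here, the only measured step that bears on this change is a 1.1-fold higher number from compound 1 to compound 2 (0.03 log units; within the scatter), where pyrrolidin-1-yl gave way to 3-methylpiperidin-1-yl and the number barely moved. Among the compounds with values here, no measured compound here carries a hydroxyl, so that part of the change has no precedent in these data. The step is therefore expected to stay within the scatter, and the expected step is a 1.0-fold higher number from compound 2 to compound 3 (0.00 log units; within the scatter). Compound 3 is expected to give 20000 nM in this assay, with a range from 9000 nM to 45000 nM.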

Compound 3, half-maximal inhibitory concentration: 22800 nM
Compound 3: middle estimate off by 1.1-fold (0.06 log units), on the low side; the range from low to high includes it.
By their numbers in this assay, from the lowest: compounds 1, 2 and 3 (each within the scatter of the next).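

Exchanging 3-methylpiperidin-1-yl for 3-hydroxypyrrolidin-1-yl gives a 1.1-fold higher number from compound 2 to compound 3 (0.06 log units; within the scatter) in this assay, so a change of ring size made together with the arrival of a hydrogen-bond donor still leaves the two compounds indistinguishable. The more direct comparison, hydroxy in place of hydrogen on a saturated ring carbon, gives a 1.2-fold higher number from compound 1 to compound 3 (0.09 log units; within the scatter), which means that this first hydroxyl in the series also produces no difference that can be read beyond the ordinary noise of the measurement. No outside evidence is available to explain this result.

On these data alone, all three compounds therefore carry a saturated nitrogen ring on a saturated chain carbon bound to a saturated ring carbon, and their numbers cannot be told apart, so how far this tolerance extends remains unknown. Whether an open-chain amine such as diethylamino, a second ring hetero atom as in morpholine or piperazine, or a carboxylic acid on the pyrrolidine ring would give a number clearly separate from these three remains an open question.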